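A few compounds are considered here, and "the series" means these few. Any claim that something is new, unique, unknown or untested is made for them only; others in the source may bear on it.

Compound 1 `CC(C)(O)C#Cc1cc(C(O)(C(F)(F)F)C(F)(F)F)cnc1N1CCN(S(=O)(=O)c2ccc(N)nc2)CC1`: 16 mL.min-1.g-1
Compound 2 `CS(=O)(=O)c1ccc(-c2cc(C(O)(C(F)(F)F)C(F)(F)F)cnc2N2CCN(S(=O)(=O)c3ccc(N)nc3)CC2)cc1`: 103 mL.min-1.g-1

Both numbers come from an ADME assay (liver) for metabolic stability, with Liver microsome (Rattus norvegicus) as the target, using microsomes and NADPH, with a stated time of 30 min, tested at 1 uM; on this read-out lower numbers stand for slow clearance and higher numbers for fast clearance. Compound 2 has the higher of the two, at 103 mL.min-1.g-1, which places it on the fast-clearance side of this small pair. Compound 3 `Nc1ccc(S(=O)(=O)N2CCN(c3ncc(C(O)(C(F)(F)F)C(F)(F)F)cc3-c3ccc4sccc4c3)CC2)cn1` has not yet been measured. It carries 1-benzothiophen-5-yl in place of 4-(methylsulfonyl)phenyl, on the same aromatic carbon, ortho to a large group: 1-benzothiophen-5-yl in place of 4-(methylsulfonyl)phenyl on an aromatic carbon. Going by the values given here, only one measured step bears on this change. It was made at the same place, where 4-(methylsulfonyl)phenyl replaced 3-hydroxy-3-methylbut-1-yn-1-yl: a 6.4-fold higher number from compound 1 to compound 2 (0.81 log units; beyond the scatter). Among the compounds with values here, no measured compound carries 1-benzothiophen-5-yl, so this single step is only a loose guide. In this assay, a smaller rise in the same direction is expected: a 2.2-fold higher number from compound 2 to compound 3 (0.35 log units; beyond the scatter). The estimate for compound 3 is 230 mL.min-1.g-1, with an expected range from 90 mL.min-1.g-1 to 500 mL.min-1.g-1.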

Compound 3, intrinsic clearance in microsomes: 487 mL.min-1.g-1
Compound 3: the middle estimate sits 2.1-fold (0.33 log units) below what was measured, within the range that was stated.
By their numbers in this assay, from the lowest: compound 1; then compound 2; then compound 3.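

This position is sensitive not only to the switch from an open chain to a ring system: exchanging one aromatic group for another on the same carbon still moves the clearance number, with a 4.7-fold higher number from compound 2 to compound 3 (0.67 log units; beyond the scatter) in this assay. Across the three groups tried at this carbon, the range is wide, with a 30-fold higher number from compound 1 to compound 3 (1.48 log units; beyond the scatter), while the rest of the molecule stays the same. Nothing available here explains why 1-benzothiophen-5-yl gives a higher number than 4-(methylsulfonyl)phenyl.

As far as these compounds go, it remains open where a plain phenyl ring, or a phenyl ring carrying a carboxylic acid or an amine, would fall on this scale. Also open, from the compounds shown here alone, is whether a saturated ring such as morpholine at this carbon would stay nearer compound 1 or nearer compound 3.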